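This account rests on a few compounds, and the source may have more. Where it says the series, first, only, none or still open, it means among the compounds named here.

Working notes on the series. Compound 1 `CN(C)C(=S)SC(=S)N1CCN(c2cccc(Cl)c2)CC1` carries 3-chlorophenyl on the ring amine nitrogen; in an ADME assay on HeLa cells (Homo sapiens) for cytotoxicity, read by MTT assay, with a stated time of 24 h (a higher number here means a weaker inhibitor, a lower number a stronger inhibitor), compound 1 gives only a limit, > 5000000 nM. Compound 2 `CN(C)C(=S)SC(=S)N1CCN(c2ncccn2)CC1` holds pyrimidin-2-yl in that place; in this assay compound 2 likewise gives only a limit, > 5000000 nM. Compound 3 `CCCCSC(=S)N1CCN(C(=S)SC(=S)N(C)C)CC1` bears butylsulfanyl on a thiocarbonyl carbon; in this assay compound 3 gives only a limit, > 5000000 nM. Compound 3 thus sits where every value of the series sits, namely (the limit of > 5000000 nM in this assay, at which 3 of the 3 values shown sit). The measured steps a step that the two limits leave unreadable from compound 1 to compound 2, a step that the two limits leave unreadable from compound 1 to compound 3 and a step that the two limits leave unreadable from compound 2 to compound 3 are all unreadable in size, so they give no direction for any further change. Compound 4 `CN(C)C(=S)SC(=S)N1CCN(C(=S)NCc2ccccc2)CC1` differs from compound 3 by benzylamino in place of butylsulfanyl on a thiocarbonyl carbon. With no readable step in the series to draw on, the change is expected to leave compound 4 at the same limit, the expected step of a number no higher from compound 3 to compound 4 (the limit leaves the size open) being flat. Compound 4 is therefore estimated at 5000000 nM, with a range from 2000000 nM to 20000000 nM.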

Compound 4, half-maximal inhibitory concentration: > 5000000 nM
Compound 4 gave a limit, no number (the forecaster's own chance of this, stated with the estimate: 85%); the middle value lies on the limit itself.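

In this assay, going by these compounds alone, compound 4, like compound 3, gives only a limit, so no step between compound 3 and compound 4 can be read: the limit of > 5000000 nM in this assay, at which 4 of the 4 values shown sit.

The compounds shown leave open where any of them truly stands in this assay and whether any change on the shared core would give a readable number.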